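Working notes: removing both bromines from compound 2

The source may hold more compounds than are shown below. What is called first, only, known or untested is meant among the compounds shown, and "the series" means these compounds.

The read-out throughout is an assay for inhibition of HSP60/HSP10 (Homo sapiens), with a stated time of 60 min; on this read-out lower numbers stand for stronger inhibition and higher numbers for weaker inhibition. Compound 1 `O=C(Nc1ccccc1)c1cccc(Br)c1` carries a single bromine on the ring attached to the carbonyl and a plain anilide. In this assay compound 1 gives only a limit, > 100000 nM. Compound 2 `O=C(Nc1ccc(Sc2nc3ccccc3s2)c(Cl)c1)c1cc(Br)cc(Br)c1` in this assay also gives only a limit, > 100000 nM. Compound 3 `O=C(Nc1ccc(Sc2nc3ccccc3s2)cc1)c1cc(Br)cc(Br)c1` in this assay likewise gives only a limit, > 100000 nM. Within the data shown here, the one step between measured neighbours, hydrogen in place of chloro on an aromatic carbon, is a step that the two limits leave unreadable from compound 2 to compound 3. All three values sit at the same point, (the limit of > 100000 nM in this assay, at which 3 of the 3 values shown sit), so nothing in the measured set can be read as a difference in strength.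

Compound 4 `O=C(Nc1ccc(Sc2nc3ccccc3s2)c(Cl)c1)c1ccccc1` differs from compound 2 by phenyl in place of 3,5-dibromophenyl on a carbonyl carbon. Among the measured compounds shown here, no measured step bears on this change, and the single step that exists is unreadable. Compound 1, which also lacks the 3,5-dibromophenyl on the carbonyl, stands at the limit > 100000 nM, so the expectation is that compound 4 remains at the limit as well. The step from compound 2 to compound 4 is therefore expected to be a step that the limit leaves unreadable from compound 2 to compound 4, with no reading possible beyond the limit. Compound 4 is estimated at 150000 nM, within 30000 nM to 1000000 nM.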

Compound 4, half-maximal inhibitory concentration: > 100000 nM
Compound 4 ended at the assay's limit; the forecaster's own chance of this, stated with the estimate: 85%; the middle value lies beyond the limit too.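

In this assay compound 4 gives > 100000 nM, a limit of the assay. Compound 2 also stands at a limit, so the step between compound 2 and compound 4 cannot be read. All values shown sit at one point: the limit of > 100000 nM in this assay, at which 4 of the 4 values shown sit. The compounds shown leave open which structural change, if any, would give a readable value.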